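Methyl on the ring carbon: a second test

A few compounds are considered here, and "the series" means these few. Any claim that something is new, unique, unknown or untested is made for them only; others in the source may bear on it.

Compound 1 `COc1cc(CC(O)(COCc2ccccc2)COCc2ccccc2)nc(OC)n1` and compound 2 `COc1nc(CC(O)(COCc2ccccc2)COCc2ccccc2)c(C)c(OC)n1` share one core; compound 3 `O=c1cc(CC(O)COCc2ccccc2)[nH]c(=O)[nH]1` carries a different core and a shorter side chain, and how the two cores differ is not broken down here. Compound 4 `Cc1c(CC(O)COCc2ccccc2)[nH]c(=O)[nH]c1=O` has not yet been measured.

In a functional assay on SW-620 cells (Homo sapiens) for antiproliferative activity, read by MTT assay, with a stated time of 72 h (on this read-out higher numbers stand for weaker inhibition and lower numbers for stronger inhibition), compound 1 gives only a limit of the assay, > 100000 nM. In this assay compound 2 gives 3500 nM. The change between them is methyl in place of hydrogen on an aromatic carbon and it produced an at least 28-fold lower number from compound 1 to compound 2 (1.45 log units; beyond the scatter). That step begins from the limit of > 100000 nM in this assay, at which 2 of the 3 values shown sit, so only a floor for its true size is known.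

In this assay compound 3 likewise gives only a limit of the assay, > 100000 nM. Compound 4 differs from compound 3 by methyl in place of hydrogen on an aromatic carbon. This is the same kind of change as from compound 1 to compound 2, not the same: in compound 1 the methyl enters ortho to a methoxy group (2 heavy atoms) and para to a methoxy group (2 heavy atoms), while in compound 3 it enters ortho to a group of 1 heavy atom and para to a group of 1 heavy atom, on a core that is not the same.

The expected step is an at least 3.3-fold lower number from compound 3 to compound 4 (0.52 log units; beyond the scatter), resting on the step of an at least 28-fold lower number from compound 1 to compound 2 (1.45 log units; beyond the scatter). Caution is warranted since compound 3 starts from the limit of > 100000 nM in this assay, at which 2 of the 3 values shown sit, and a measurable number may still not be reached. Compound 4 is estimated at 30000 nM, expected within 5000 nM to 150000 nM.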

Compound 4, half-maximal inhibitory concentration: > 100000 nM
Compound 4: no number, only a limit; the forecaster's own chance of this, stated with the estimate: 45%; middle value at least 3.3-fold (0.52 log units) away from the limit.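

In this assay compound 4 gives > 100000 nM, a limit of the assay and not a number. Compound 3 also gives only a limit, so no step between compound 3 and compound 4 can be read: the limit of > 100000 nM in this assay, at which 3 of the 4 values shown sit.

The compounds shown leave open whether methyl in place of hydrogen on an aromatic carbon lowers the number at all on the core of compound 3.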